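Adding a second fluoro to compound 3

The source may hold more compounds than are shown below. What is called first, only, known or untested is meant among the compounds shown, and "the series" means these compounds.

Measured in a functional assay on Jurkat cells (Homo sapiens); on this read-out higher numbers stand for weaker inhibition and lower numbers for stronger inhibition:
- compound 1 `CC(C)[C@H](NC(=O)COc1cccc2ccccc12)C(=O)N[C@@H](CC(=O)O)C(=O)COc1cccc2ccccc12`: > 100000 nM
- compound 2 `CC(C)[C@H](NC(=O)COc1cccc2ccccc12)C(=O)N[C@@H](CC(=O)O)C(=O)COc1ccc(OC(F)(F)F)cc1`: 29100 nM
- compound 3 `CC(C)[C@H](NC(=O)COc1cccc2ccccc12)C(=O)N[C@@H](CC(=O)O)C(=O)COc1ccc(F)cc1`: > 100000 nM

Compound 3 gives > 100000 nM, which is a limit and not a number. Compound 1 gives > 100000 nM, also a limit. Together they stand at the limit of > 100000 nM in this assay, at which 2 of the 3 values shown sit. Only compound 2 gives a number, 29100 nM.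

Compound 4 `CC(C)[C@H](NC(=O)COc1cccc2ccccc12)C(=O)N[C@@H](CC(=O)O)C(=O)COc1ccc(F)c(F)c1` carries fluoro in place of hydrogen on an aromatic carbon, ortho to a fluoro group and meta to a large group: fluoro in place of hydrogen on an aromatic carbon.

The closest measured change is an at least 3.4-fold higher number from compound 2 to compound 3 (0.53 log units; beyond the scatter). Beside it stands an at least 3.4-fold lower number from compound 1 to compound 2 (0.53 log units; beyond the scatter), while a step that the two limits leave unreadable from compound 1 to compound 3 cannot be sized. None of these steps adds a fluoro to a ring already bearing one, so they only loosely bear on this change. With compound 3 at > 100000 nM, a modest move towards lower numbers is expected in this assay, and a result at the same limit is the likeliest outcome. The expected change is an at least 1.2-fold lower number from compound 3 to compound 4 (0.09 log units; that floor lies within the scatter). For compound 4 the estimate is 80000 nM, with an expected range from 25000 nM to 200000 nM.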

Compound 4, half-maximal inhibitory concentration: > 100000 nM
Compound 4: no number, only a limit (the forecaster's own chance of this, stated with the estimate: 65%); middle value at least 1.2-fold (0.09 log units) from the limit.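

In this assay compound 4 gives > 100000 nM as a limit and not a number. For the compounds shown here, a second fluoro, ortho to a fluoro group, does not bring the 4-fluorophenyl compound off the limit, and 3,4-difluorophenyl in place of 4-(trifluoromethoxy)phenyl gives an at least 3.4-fold higher number from compound 2 to compound 4 (0.53 log units; beyond the scatter) and leaves compound 2 as the only compound with a number. The steps to compound 4 from compound 3 and from compound 1 cannot be read, and the series now sits mostly at one value: the limit of > 100000 nM in this assay, at which 3 of the 4 values shown sit.

Any effect of the second fluoro remains hidden behind the limit. Also open, going by these compounds, is whether a trifluoromethyl or a methoxy group in place of the fluoro of compound 3 would give a number, as the trifluoromethoxy group of compound 2 does.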